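From Phenyl to sec-Butyl on a Saturated Ring Carbon

The source may hold more compounds than are shown below. What is called first, only, known or untested is meant among the compounds shown, and "the series" means these compounds.

Of the compounds shown here, three have so far been tested in a functional assay on HeLa cells (Homo sapiens) for inhibition; on this read-out lower numbers stand for stronger inhibition and higher numbers for weaker inhibition. Compound 1 `CCC(C)C(NC(=O)NO)C(=O)NCc1ccccc1` reaches the limit of the assay, > 100000 nM. Compound 2 `CC(C)C1NC(=O)N(C2CCCC2)C1=O` likewise returns a limit, > 100000 nM. Compound 3 `O=C1NC(c2ccccc2)C(=O)N1Cc1ccccc1` also sits at a limit, > 100000 nM. All three therefore share (the limit of > 100000 nM in this assay, at which 3 of the 3 values shown sit), and compound 3 stands nowhere apart from compound 1 or compound 2 on the numbers shown. Compound 4 `CCC(C)C1NC(=O)N(Cc2ccccc2)C1=O` differs from compound 3 by sec-butyl in place of phenyl on a saturated ring carbon. Among the measured compounds shown here, no step between measured compounds exists to size this change. The step that the limit leaves unreadable from compound 3 to compound 4 is expected to be none beyond the scatter. Compound 4 is accordingly estimated at 200000 nM in this assay, within 50000 nM to 1000000 nM, most probably reported again as a limit.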

Compound 4, half-maximal inhibitory concentration: > 100000 nM
Compound 4: no number, only a limit; the forecaster's own chance of this, stated with the estimate: 85%; the middle value does not contradict the limit.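

Compound 3 and compound 4 both stand at a limit and not at a number, so no step can be read between them: the limit of > 100000 nM in this assay, at which 4 of the 4 values shown sit.

The compounds shown leave open what structure, if any, would give a measurable value in this assay.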